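The source may report more compounds than this note shows. Statements on the series, on what has been measured and on what is new or still open speak of the compounds shown alone.

Compound 1 `COc1ccc(-c2cc(=O)c3ccc(OC)cc3o2)cc1`: 49700 nM in an in vitro assay on BTI-TN-5B1-4 cells for inhibition of Amine oxidase [flavin-containing] B (Homo sapiens); on this read-out higher numbers stand for weaker inhibition and lower numbers for stronger inhibition
Compound 2 `COc1ccc(-c2cc(=O)c3ccc(F)cc3o2)cc1`: 1340 nM in this assay

Going by the values given here, on these two numbers compound 1 stands highest; its only neighbour is compound 2, reached by a 37-fold lower number from compound 1 to compound 2 (1.57 log units; beyond the scatter), a fluoro in place of methoxy on an aromatic carbon. Compound 3 `COc1ccc2c(=O)cc(-c3ccc(F)cc3)oc2c1` has not yet been measured in this assay. It differs from compound 1 as follows: fluoro in place of methoxy on an aromatic carbon. Among the compounds with values here, the single measured step, from compound 1 to compound 2, is the same exchange of methoxy for fluoro, but made at a different aromatic carbon of the shared core, so it bears on compound 3 only as a like-for-like swap carried out elsewhere; that step was large, a 37-fold lower number from compound 1 to compound 2 (1.57 log units; beyond the scatter). Within the data shown here, no step at the place of the present change has been measured. A lower number is therefore expected for compound 3, though with less confidence and of smaller size than the measured step. The estimate for compound 3 is 12000 nM, between 2500 nM and 50000 nM. This estimate corresponds to an expected step of a 4.1-fold lower number from compound 1 to compound 3 (0.62 log units; beyond the scatter).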

Compound 3, half-maximal inhibitory concentration: 5140 nM
Estimate against measurement, compound 3: 2.3-fold (0.37 log units) above, within the range that was stated.
By their numbers in this assay, from the lowest: compound 2; then compound 3; then compound 1.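

The exchange of methoxy for fluoro on the six-membered aromatic ring of carbon only, para to a large group, also lowers the number in this assay (a 9.7-fold lower number from compound 1 to compound 3 (0.99 log units; beyond the scatter)), so the lowering seen earlier is not confined to the other aromatic carbon of the shared core. The step at this place is modest, whereas the same exchange at the other place is large (a 37-fold lower number from compound 1 to compound 2 (1.57 log units; beyond the scatter)), so the two places of compound 1 do not respond to this swap to the same extent. Nothing available on these compounds accounts for either step or for the difference in their size.

The compounds shown leave open whether the lower number at this place follows from the loss of methoxy or from the arrival of fluoro, a question that a compound with plain hydrogen, chloro or an amine at the same carbon would help to settle. They also leave open how a compound carrying fluoro at both places would stand against compound 2 and compound 3.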